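The source may report more compounds than this note shows. Statements on the series, on what has been measured and on what is new or still open speak of the compounds shown alone.

Measured compounds in a functional assay on the whole organism with Rattus norvegicus as the target; a higher number here means that more compound is needed for the effect, a lower number that less compound is needed:
Compound 1 `Nc1nc2ccc(OCC(F)(F)F)cc2s1` gives 6.5 mg/kg.
Compound 2 `Nc1nc2cccc(OC(F)(F)F)c2s1` gives > 10 mg/kg, which is a limit of the assay and not a number.
Compound 3 `CCCn1c(=N)sc2cc(OC(F)(F)F)ccc21` gives 4.5 mg/kg.

Of the two numbers in this assay, compound 3 has the lowest, and its nearest neighbour is compound 1; the gap between compound 3 and compound 1 lies within the scatter, so no order between them can be read from these two values. The result for compound 2 stands only as a limit of > 10 mg/kg in this assay, at which 1 of the 3 values shown sits, and does not rank against the others. For the measured compounds named here, no pair of measured compounds differs in a single place, so no measured step is available.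

Compound 4 `N=c1sc2cc(OC(F)(F)F)ccc2n1CCO` is the next compound for this assay. It differs from compound 3 by hydroxy in place of methyl on a saturated chain carbon, two bonds along the chain from an aromatic nitrogen. Going by the values given here, no measured pair shows what this kind of change does, so the expectation rests only on the value of compound 3. The step from compound 3 to compound 4 in this assay is expected to be small, a 1.1-fold higher number from compound 3 to compound 4 (0.05 log units; within the scatter), not beyond the scatter in either direction. Compound 4 is accordingly estimated at 5 mg/kg, with a range from 2.5 mg/kg to 10 mg/kg.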

Compound 4, dose for half-maximal effect: 8 mg/kg
Estimate against measurement, compound 4: 1.6-fold (0.20 log units) below; the measured number falls inside the stated range.
By their numbers in this assay, from the lowest: compounds 3, 1 and 4 (each within the scatter of the next). At a limit, above all of these: compound 2.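

In this assay, for the compounds shown here, hydroxy in place of methyl on a saturated chain carbon, two bonds along the chain from an aromatic nitrogen, gives a 1.8-fold higher number from compound 3 to compound 4 (0.25 log units; within the scatter) and supplies the first measured single-place step. The earlier compounds shown here could not speak to this position, whereas this pair shows that going from the propyl chain to the 2-hydroxyethyl chain, which brings one hydrogen-bond donor and one hydrogen-bond acceptor, leaves the whole-animal dose indistinguishable within the scatter. Nothing at hand bears on what lies behind this step.

This single pair leaves open whether the position stays as undemanding with groups of a different kind, such as a terminal amine or carboxylic acid on the same chain, or with a longer chain carrying the hydroxy. Going by these compounds alone, it also leaves open whether the same exchange would give a similar step on a core with another substituent pattern, since no second pair of this kind stands.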